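The compounds below may be only part of what the source reports. "The series", "measured", "known", "first", "only" and "open" are said of these compounds alone.

Compound 3 `CCOC(=O)C1=Cc2ccccc2OC1(OCc1cc(-c2cccc(C(F)(F)F)c2)no1)C(F)(F)F` carries a 3-(trifluoromethyl)phenyl group and in a functional assay on DU-145 cells (Homo sapiens) for inhibition, read by MTT assay, with a stated time of 24 h (a lower number here means a stronger inhibitor, a higher number a weaker inhibitor), gives 57300 nM, the higher of the two numbers obtained so far. Compound 2 `CCOC(=O)C1=Cc2ccccc2OC1(OCc1cc(-c2ccc(Cl)cc2)no1)C(F)(F)F` gives 18200 nM in this assay. Compound 1 `CCOC(=O)C1=Cc2ccccc2OC1(OCc1cc(-c2ccc(F)cc2F)no1)C(F)(F)F` reaches only a limit in this assay, > 150000 nM, and not a number (the limit of > 150000 nM in this assay, at which 1 of the 3 values shown sits). Compound 4 `CCOC(=O)C1=Cc2ccccc2OC1(OCc1cc(-c2ccc(F)cc2)no1)C(F)(F)F` differs from compound 3 in one place: 4-fluorophenyl in place of 3-(trifluoromethyl)phenyl on an aromatic carbon. The measured step that bears most on this is a 3.1-fold higher number from compound 2 to compound 3 (0.50 log units; beyond the scatter), where the 4-chlorophenyl ring gave the lower number, while an at least 2.6-fold lower number from compound 1 to compound 3 (0.41 log units; beyond the scatter) shows the 2,4-difluorophenyl ring to be weaker still. A single fluorine on the ring is expected to behave more like the chlorine case, so a small step toward a lower number, a 1.9-fold lower number from compound 3 to compound 4 (0.28 log units; within the scatter), is expected. Compound 4 is therefore estimated at 30000 nM, within 10000 nM to 120000 nM.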

Compound 4, half-maximal inhibitory concentration: 53500 nM
Compound 4: the middle estimate sits 1.8-fold (0.25 log units) below what was measured, within the range that was stated.
By their numbers in this assay, from the lowest: compound 2; then compounds 4 and 3 (each within the scatter of the next). At a limit, above all of these: compound 1.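

In this assay, 4-fluorophenyl in place of 3-(trifluoromethyl)phenyl makes no readable difference, a 1.1-fold lower number from compound 3 to compound 4 (0.03 log units; within the scatter), so a single fluorine does not bring the number toward that of compound 2. The halogen alone does count at this position, since fluoro in place of chloro gives a 2.9-fold higher number from compound 2 to compound 4 (0.47 log units; beyond the scatter). Hydrogen in place of the second fluoro gives an at least 2.8-fold lower number from compound 1 to compound 4 (0.44 log units; beyond the scatter), and the value of compound 1 is a limit, not a number: the limit of > 150000 nM in this assay, at which 1 of the 4 values shown sits. The compounds shown leave open whether an amine, a carboxylic acid or a methoxy group on this phenyl ring would give a lower number than compound 2.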